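Alkoxy for amino on a purine-like core

The source may report more compounds than this note shows. Statements on the series, on what has been measured and on what is new or still open speak of the compounds shown alone.

Compound 3 `CCCC(CC)Nc1nc(C)nc2c1ncn2-c1ccc(C(C)C)cc1Br` gives 4.4 nM in an in vitro assay on 293-EBNA cells for binding affinity to corticotropin-releasing factor receptor 1 (Homo sapiens) (on this read-out lower numbers stand for stronger inhibition and higher numbers for weaker inhibition), the second highest of three values and within the scatter of compound 1 `CCCCN(CC)c1nc(C)nc2c1ncn2-c1ccc(C(C)C)cc1Br` at 4.3 nM; compound 2 `COCCNc1nc(C)nc2c1ncn2-c1ccc(C(C)C)cc1Br` at 210 nM sits far from both. Compound 4 `CCC(COC)Oc1nc(C)nc2c1ncn2-c1ccc(C(C)C)cc1Br` differs by 1-(methoxymethyl)propoxy in place of (1-ethylbutyl)amino on an aromatic carbon. Among the compounds with values here, the steps that bear on this are a 49-fold higher number from compound 1 to compound 2 (1.69 log units; beyond the scatter) and a 48-fold lower number from compound 2 to compound 3 (1.68 log units; beyond the scatter), both large and both following the introduction of a methoxyethyl group in place of a branched alkyl chain. The change to compound 4 keeps the heavy-atom count but trades the donor for a second acceptor, so a weakening step is expected, smaller than those two: the estimated step is a 6.8-fold higher number from compound 3 to compound 4 (0.83 log units; beyond the scatter). Compound 4 is therefore expected at 30 nM, between 8 nM and 150 nM.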

Compound 4, inhibition constant: 9.7 nM
The estimate for compound 4 lay 3.1-fold (0.49 log units) above the measured number; measured number inside the range.
By their numbers in this assay, from the lowest: compounds 1 and 3 (each within the scatter of the next); then compound 4; then compound 2.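

Putting 1-(methoxymethyl)propoxy on this aromatic carbon, next to the ring nitrogen, costs little in this assay: a 2.2-fold higher number from compound 3 to compound 4 (0.34 log units; beyond the scatter) and a 2.3-fold higher number from compound 1 to compound 4 (0.35 log units; beyond the scatter) are both modest, though beyond the scatter. The larger step of a 22-fold lower number from compound 2 to compound 4 (1.34 log units; beyond the scatter) shows that a chain ending in methoxy need not give a number as high as that of compound 2. Going by these compounds, whether the oxygen link or the branched chain accounts for that larger step remains open, as does how 1-ethylbutoxy would compare at this position. No supporting evidence gives a cause for any of these steps.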